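The source may report more compounds than this note shows. Statements on the series, on what has been measured and on what is new or still open speak of the compounds shown alone.

In a functional assay on the whole organism with Rattus norvegicus as the target, at a dose of 40 mg/kg by the intraperitoneal route (on this read-out lower numbers stand for less inhibition and higher numbers for more inhibition at the one dose given (going by the name of the read-out)), three compounds have been measured:

compound 1 `Cc1cc(OCc2ccccc2)c2nc(C)c(C)n2c1` — 86%
compound 2 `Cc1nc2c(OCc3ccccc3)cccn2c1N` — 99%
compound 3 `Nc1cnc2c(OCc3ccccc3)cccn12` — 32%

Compound 3 gives the lowest of these three numbers. Compound 1 stands higher by a margin beyond the scatter, and compound 2 stands higher still, again beyond the scatter.

Compound 4 `CCc1nc2c(OCc3ccccc3)cccn2c1N` differs from compound 3 by ethyl in place of hydrogen on an aromatic carbon. Going by the values given here, one measured step bears directly on this change: a number 67 percentage points lower from compound 2 to compound 3 (beyond the scatter). That step runs in the opposite direction, replacing an alkyl group with hydrogen on the same aromatic carbon, and it was large. Compound 4 puts an alkyl group back at that carbon, though ethyl rather than methyl, so the change is not an exact reversal. On the strength of the step from compound 2 to compound 3, a large rise in this assay is expected for compound 4, of about a number 56 percentage points higher from compound 3 to compound 4 (beyond the scatter). Among the compounds with values here, the number for compound 4 is therefore estimated at 88%, with a range from 60% to 100%; the wider lower end reflects that ethyl, not methyl, enters and that only one step informs the guess.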

Compound 4, a percentage reported as inhibition, in the whole organism at one dose (the size of the read-out at that dose, not a potency): 83%
Estimate against measurement, compound 4: 5 percentage points above, and the stated range covers the measured number.
By their numbers in this assay, from the lowest: compound 3; then compounds 4 and 1 (each within the scatter of the next); then compound 2.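

The change from hydrogen to ethyl gives a number 51 percentage points higher from compound 3 to compound 4 (beyond the scatter) in this assay, so the high read-out at this aromatic carbon is not confined to methyl. The two alkyl groups are not interchangeable, however: extending methyl to ethyl gives a number 16 percentage points lower from compound 2 to compound 4 (beyond the scatter) and so costs a modest part of the read-out. Among the three groups seen at this carbon, hydrogen gives by far the lowest number, and the step from methyl to ethyl is much smaller than either step from an alkyl group to hydrogen. Nothing available explains these differences. On these data alone, what a longer chain such as propyl, a branched group such as isopropyl, or a polar group such as a carboxylic acid would do at this carbon stays open. So does whether the modest decline from methyl to ethyl continues as the chain grows.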